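Chain lengthening on the saturated chain, one measured anchor

The source may hold more compounds than are shown below. What is called first, only, known or untested is meant among the compounds shown, and "the series" means these compounds.

Of the compounds shown here, two have been measured in an ADME assay on HeLa cells (Homo sapiens) for inhibition, read by MTT assay; a higher number here means a weaker inhibitor of growth, a lower number a stronger inhibitor of growth. Compound 1 `CCCCCc1cc2c(=O)n(CCCSc3nc(-c4cc(OC)c(OC)c(OC)c4)c(C#N)c(=O)[nH]3)cnc2s1` gives 75.8 ug/mL in this assay. Compound 2 `CCCCCCc1cc2c(=O)n(CCSc3nc(-c4cc(OC)c(OC)c(OC)c4)c(C#N)c(=O)[nH]3)cnc2s1` gives 76.3 ug/mL in this assay. On the two numbers shown, compound 1 stands at the low end, with compound 2 within the scatter of it, so the two readings cannot be ranked against each other.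

Compound 3 `CCCCCCc1cc2c(=O)n(CCCSc3nc(-c4cc(OC)c(OC)c(OC)c4)c(C#N)c(=O)[nH]3)cnc2s1` has not yet been measured in this assay. Relative to compound 1 the change is methyl in place of hydrogen on a saturated chain carbon, five bonds along the chain from an aromatic carbon. For the measured compounds named here, no step between measured compounds covers this change, so nothing in the data anchors its size or direction. Compound 1 and compound 2, which differ from each other in two places at once, both read close to the same number, which gives no hint of a large effect from changes on the saturated chain. For compound 3 the step of a 1.1-fold lower number from compound 1 to compound 3 (0.02 log units; within the scatter) is expected to stay within the scatter, with no direction favoured. Compound 3 is estimated at 72 ug/mL in this assay, with a range from 36 ug/mL to 145 ug/mL.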

Compound 3, concentration for 50% growth inhibition: 67 ug/mL
Estimate against measurement, compound 3: 1.1-fold (0.03 log units) above; low and high end bracket the measured number.
By their numbers in this assay, from the lowest: compounds 3, 1 and 2 (each within the scatter of the next).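

In this assay, a 1.1-fold lower number from compound 1 to compound 3 (0.05 log units; within the scatter) gives the first size for methyl in place of hydrogen on a saturated chain carbon, five bonds along the chain from an aromatic carbon. For the compounds shown here, the earlier data held no pair differing in this one place, so this single change now has a direct reading, and that reading shows no effect that can be told from the scatter at this position. Nothing measured bears on why the reading stays within the scatter here.

This single step covers only the addition of one methyl at this carbon, on one background, so it does not show whether a much longer chain, a branched chain, or a chain ending in an amine or a carboxylic acid would also stay within the scatter. It also leaves open whether the same methyl change would read the same way on a compound with a different trimethoxyphenyl replacement, such as a plain phenyl ring, in this assay.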